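A few compounds are considered here, and "the series" means these few. Any claim that something is new, unique, unknown or untested is made for them only; others in the source may bear on it.

Two hydroxamic acids sharing one core have been measured in an assay on Sf9 cells for inhibition of protein deacetylase HDAC6 (Homo sapiens), read by fluorescence, with a stated time of 40 min, tested at 100 nM; on this read-out higher numbers stand for more inhibition at the one concentration tested (going by the name of the read-out) and lower numbers for less inhibition. Compound 1 `Cc1ccccc1-n1nc(-c2ccccc2)nc1CNc1ccc(C(=O)NO)cc1` gives 57.1% in this assay. Compound 2 `Cc1ccc(-c2nc(CNc3ccc(C(=O)NO)cc3)n(-c3ccccc3)n2)cc1` gives 62.2% in this assay; the numbers of compound 2 and compound 1 lie within the usual scatter of each other, so the two cannot be told apart on these data. Compound 3 `O=C(NO)c1ccc(NCc2nc(-c3ccc(Br)cc3)nn2-c2ccccc2)cc1` has not yet been measured. It differs from compound 2 only by bromo in place of methyl on an aromatic carbon. Going by the values given here, no pair of measured compounds shows what such a change does here, so there is no measured step to lean on. The expected step from compound 2 to compound 3 in this assay is small, a number 0.2 percentage points lower from compound 2 to compound 3 (within the scatter), not beyond the scatter in either direction. Compound 3 is therefore estimated to give 62% in this assay, within a range from 45% to 78%.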

Compound 3, a percentage reported as inhibition, at one concentration (the size of the read-out at that concentration, not a potency): 54.7%
Compound 3: the middle estimate sits 7.3 percentage points above what was measured; the range from low to high includes it.
By their numbers in this assay, from the lowest: compounds 3, 1 and 2 (each within the scatter of the next).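

In this assay, going by these compounds alone, the change from 4-methylphenyl to 4-bromophenyl gives the only measured step at this position, a number 7.5 percentage points lower from compound 2 to compound 3 (within the scatter). On these data, bromo and methyl on this aromatic carbon, para to a large group, therefore cannot be told apart, and the position holds either group without a difference that this read-out can resolve at its one tested concentration. Nothing measured here bears on why the step has this size.

The compounds shown leave open whether a different kind of group at this place, such as an amine, a carboxylic acid or a longer chain, would give a step beyond the scatter. Because the read-out reflects a single concentration, they also leave open how the potencies of compound 2 and compound 3 compare.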